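A few compounds are considered here, and "the series" means these few. Any claim that something is new, unique, unknown or untested is made for them only; others in the source may bear on it.

In a functional assay on the whole organism (blood, strain Wistar-Okamoto) with Rattus norvegicus as the target, with a stated time of 5 days (on this read-out lower numbers stand for an effect already at smaller amounts and higher numbers for an effect only at larger amounts of compound), three compounds have been measured so far. Compound 1 `CCC(CC)/N=C(\NC#N)Nc1cccnc1` gives a value of 20 mg/kg. Compound 2 `CCC(C)(C)N/C(=N\c1ncccn1)Nc1cccnc1` gives only a limit of the assay, > 35 mg/kg, which is not a number. Compound 3 `CC(C)(C)N/C(=N\C#N)Nc1ccc(O)cc1` likewise gives only a limit, > 50 mg/kg, so its true minimum effective dose is not known. Of the three values shown, two are limits: one sits at the limit of > 35 mg/kg in this assay, at which 1 of the 3 values shown sits, and the other, that of compound 3, at the limit of > 50 mg/kg in this assay, at which 1 of the 3 values shown sits. No pair of these compounds differs in a single place, so no measured step is available to guide an expectation.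

Compound 4 `CC(=O)Nc1ccc(N/C(=N/C#N)NC(C)(C)C)cc1` has not yet been measured. It differs from compound 3 in one place: acetamido in place of hydroxy on an aromatic carbon. Without a measured step of this kind, the expectation rests on the shared core and the limit for compound 3. The step is estimated at a number no higher from compound 3 to compound 4 (the limit leaves the size open), which means no change beyond the usual scatter. Compound 4 is therefore expected to give about 50 mg/kg, with a range from 20 mg/kg to 120 mg/kg, and it may well again reach only a limit.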

Compound 4, minimum effective dose: > 50 mg/kg
Compound 4 gave a limit, no number (the forecaster's own chance of this, stated with the estimate: 65%); the middle value lies on the limit itself.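

Compound 3 and compound 4 both give only a limit in this assay, not a number, and no step can be read between them. The compounds shown leave open whether acetamido in place of hydroxy changes the minimum effective dose at all.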